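Adding a Second Chloro to the Aryl Ring

The source may hold more compounds than are shown below. What is called first, only, known or untested is meant among the compounds shown, and "the series" means these compounds.

Measured compounds:
compound 1 `Cc1c(/N=C/c2cccc(O)c2)c(=O)n(-c2ccccc2)n1C` — 437000000 nM
compound 2 `COc1ccccc1/C=N/c1c(C)n(C)n(-c2ccccc2)c1=O` — 229000000 nM
compound 3 `Cc1c(/N=C/c2ccc(Cl)cc2)c(=O)n(-c2ccccc2)n1C` — 646000000 nM

In a functional assay on P388 cells (Mus musculus) for cytotoxicity, read by MTT assay, with a stated time of 72 h (on this read-out higher numbers stand for weaker inhibition and lower numbers for stronger inhibition), compound 3 gives the highest of the three numbers, separated from its nearest neighbour by a 1.5-fold higher number from compound 1 to compound 3 (0.17 log units; within the scatter) and from the furthest by a 2.8-fold higher number from compound 2 to compound 3 (0.45 log units; beyond the scatter). Compound 4 `Cc1c(/N=C/c2ccc(Cl)cc2Cl)c(=O)n(-c2ccccc2)n1C` is compound 3 with chloro in place of hydrogen on an aromatic carbon. Among the compounds with values here, no measured step adds a chloro to a ring that already carries one; the steps that exchange the whole aryl group moved the numbers by a 1.9-fold lower number from compound 1 to compound 2 (0.28 log units; within the scatter), a 1.5-fold higher number from compound 1 to compound 3 (0.17 log units; within the scatter) and a 2.8-fold higher number from compound 2 to compound 3 (0.45 log units; beyond the scatter), only one of them beyond the scatter. The expected step is therefore small, a 1.1-fold lower number from compound 3 to compound 4 (0.03 log units; within the scatter), with no clear direction. Compound 4 is estimated at 600000000 nM, within a range from 200000000 nM to 2000000000 nM.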

Compound 4, half-maximal inhibitory concentration: 363000000 nM
The estimate for compound 4 lay 1.7-fold (0.22 log units) above the measured number; low and high end bracket the measured number.
By their numbers in this assay, from the lowest: compounds 2, 4, 1 and 3 (each within the scatter of the next, the first and the last beyond it).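

In this assay, within the data shown here, this is the first step that adds a chloro to a ring already carrying one, and at this place, ortho to a large group and meta to a chloro group, it gives a 1.8-fold lower number from compound 3 to compound 4 (0.25 log units; within the scatter). The 2,4-dichlorophenyl group also stays within the scatter of the other two aryl groups, with a 1.6-fold higher number from compound 2 to compound 4 (0.20 log units; within the scatter) and a 1.2-fold lower number from compound 1 to compound 4 (0.08 log units; within the scatter). Nothing available bears on the reason for these small steps. On these data alone, whether an amine or a carboxylic acid at this place would give a step beyond the scatter stays open. So does whether a chloro here would give a similar number without the second chloro on the ring.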